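The source may report more compounds than this note shows. Statements on the series, on what has been measured and on what is new or still open speak of the compounds shown alone.

Measured so far in a functional assay on HCT-116 cells (Homo sapiens) for antiproliferative activity, read by MTT assay, with a stated time of 72 h; a lower number here means a stronger inhibitor, a higher number a weaker inhibitor 

- compound 1 `CC(C)C[C@H](NC(=O)CNC(=O)N1C/C(=C\c2ccc(F)cc2)C(=O)/C(=C/c2ccc(F)cc2)C1)B1OC(C)(C)C(C)(C)O1` gives 375 nM 
- compound 2 `CC1(C)OB([C@H](CCc2ccccc2)NC(=O)N2C/C(=C\c3ccc(F)cc3)C(=O)/C(=C/c3ccc(F)cc3)C2)OC1(C)C` gives 1040 nM 
- compound 3 `CC(C)[C@H](NC(=O)N1C/C(=C\c2ccc(F)cc2)C(=O)/C(=C/c2ccc(F)cc2)C1)B1OC(C)(C)C(C)(C)O1` gives 908 nM 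

Compound 2 (1040 nM) and compound 3 (908 nM) sit within the scatter of each other, while compound 1 (375 nM) shows a clearly lower number.

Compound 4 `CC(C)C[C@H](NC(=O)N1C/C(=C\c2ccc(F)cc2)C(=O)/C(=C/c2ccc(F)cc2)C1)B1OC(C)(C)C(C)(C)O1` keeps the core of compound 2 and changes one group (isopropyl in place of benzyl on a saturated chain carbon, two bonds along the chain from an amide-type nitrogen and a boron atom). This puts isopropyl in place of benzyl on a saturated chain carbon, two bonds along the chain from an amide-type nitrogen and a boron atom. Read one bond further out, the change is phenethyl to isobutyl.

The measured step closest to this also removes phenethyl, and it was small (a 1.1-fold lower number from compound 2 to compound 3 (0.06 log units; within the scatter)). Compound 1 (375 nM) also carries isobutyl but differs from compound 4 elsewhere as well, so it gives only a weak pull towards a lower number. The expected change is slight and stays within the scatter (a 1.4-fold lower number from compound 2 to compound 4 (0.14 log units; within the scatter)). Compound 4 is estimated at 750 nM, with an expected range from 350 nM to 1500 nM in this assay here.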

Compound 4, half-maximal inhibitory concentration: 824 nM
The estimate for compound 4 lay 1.1-fold (0.04 log units) below the measured number; the range from low to high includes it.
By their numbers in this assay, from the lowest: compound 1; then compounds 4, 3 and 2 (each within the scatter of the next).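

Compound 4 shows that a second group without a ring, isobutyl, can replace phenethyl at this position with little effect in this assay: the change is a 1.3-fold lower number from compound 2 to compound 4 (0.10 log units; within the scatter). Lengthening isopropyl to isobutyl on the same carbon also makes little difference, giving a 1.1-fold lower number from compound 3 to compound 4 (0.04 log units; within the scatter), so compounds 2, 3 and 4 read alike despite the loss of the aromatic ring and the change in group size. No measurement shown here explains why these three groups give such similar numbers.

As far as these compounds go, all three groups contain only carbon and hydrogen, so it remains open whether an amine or a carboxylic acid at this position would shift the number. It is also unknown whether these groups would still read alike on a different core.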